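A few compounds are considered here, and "the series" means these few. Any claim that something is new, unique, unknown or untested is made for them only; others in the source may bear on it.

In a functional assay on MCF7 cells (Homo sapiens) for cytotoxicity, read by trypan blue exclusion, with a stated time of 48 h (a higher number here means a weaker inhibitor, a lower number a stronger inhibitor), compound 1 (`Cc1cc(C(=O)c2ccccc2Br)ccc1OCC(=O)NNC(=O)c1cc2ccccc2oc1=O`) gives 7700 nM. Compound 2 (`Cc1ccc(C(=O)c2cc(F)c(OCC(=O)NNC(=O)c3cc4ccccc4oc3=O)c(Cl)c2)cc1`) gives 9400 nM. Among the compounds with values here, these two numbers lie within the scatter of each other, so compound 1 stands level with the only other measured member of the series. Compound 3 (`Cc1cc(C(=O)c2ccc(Cl)cc2Cl)ccc1OCC(=O)NNC(=O)c1cc2ccccc2oc1=O`) has no number yet in this assay. Its change from compound 1 is 2,4-dichlorophenyl in place of 2-bromophenyl on a carbonyl carbon. Within the data shown here, no measured pair differs at one place only, so the size of this change has no direct precedent, and the range must stay wide. Among the measured compounds shown here, with only two closely spaced values as a guide, no shift beyond the scatter is expected in this assay. The expected step is a 1.0-fold lower number from compound 1 to compound 3 (0.01 log units; within the scatter), with no direction claimed. For compound 3 the estimated value is 7500 nM, with an expected range of 2500 nM to 20000 nM.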

Compound 3, half-maximal inhibitory concentration: 10400 nM
Compound 3: middle estimate off by 1.4-fold (0.14 log units), on the low side; the range from low to high includes it.
By their numbers in this assay, from the lowest: compounds 1, 2 and 3 (each within the scatter of the next).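

In this assay, the group on the carbonyl carbon now has its first direct comparison: 2,4-dichlorophenyl in place of 2-bromophenyl gives a 1.4-fold higher number from compound 1 to compound 3 (0.13 log units; within the scatter). For this pair, then, exchanging one halogen-bearing phenyl for another, with one more heavy atom and the same count of hydrogen-bond donors and acceptors, produces no step beyond the scatter. No measurement is available that bears on why these two groups read alike.

On these data alone, both groups in this pair are halogen-bearing phenyl rings, so it remains open whether a cyclohexyl group, or a phenyl carrying an amine or a carboxylic acid, at this carbonyl carbon would give a step beyond the scatter. As far as these compounds go, the rest of the core of compound 1 stays constant in this pair, so the effect of a change there also remains open.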